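A Fluorine Swap on a Shared Core, Tested on PC-3 Cells

The source may hold more compounds than are shown below. What is called first, only, known or untested is meant among the compounds shown, and "the series" means these compounds.

compound 1, `COc1ccc2[nH]cc(/C=C(\C#N)C(=O)c3c[nH]c4ccccc34)c2c1`: 33200 nM
compound 2, `N#C/C(=C\c1c[nH]c2cc(F)ccc12)C(=O)c1c[nH]c2cc(F)ccc12`: a limit of the assay, > 50000 nM
compound 3, `N#C/C(=C\c1c[nH]c2cc(F)ccc12)C(=O)c1c[nH]c2ccccc12`: a limit of the assay, > 50000 nM

In a functional assay on PC-3 cells (Homo sapiens) for cytotoxicity, read by WST assay, with a stated time of 24 h (on this read-out higher numbers stand for weaker inhibition and lower numbers for stronger inhibition), compound 1 is the only one of the three that gives a number. The difference between the core of compound 1 and the core of compound 3 is not broken down here. From compound 3 to compound 2 the change is fluoro in place of hydrogen on an aromatic carbon, and the step that the two limits leave unreadable from compound 3 to compound 2 cannot be read because both sit at the limit of > 50000 nM in this assay, at which 2 of the 3 values shown sit. Compound 4, `COc1ccc2[nH]cc(/C=C(\C#N)C(=O)c3c[nH]c4cc(F)ccc34)c2c1`, differs from compound 1 by the same change, (fluoro in place of hydrogen on an aromatic carbon). With the measured step unreadable, the step from compound 1 to compound 4 in this assay is expected to be small, a 1.2-fold higher number from compound 1 to compound 4 (0.08 log units; within the scatter). Compound 4 is therefore estimated at 40000 nM, between 15000 nM and 100000 nM.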

Compound 4, half-maximal inhibitory concentration: > 50000 nM
Compound 4: no number, only a limit; the forecaster's own chance of this, stated with the estimate: 35%; at least 1.2-fold (0.09 log units) between middle value and limit.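

Carried to the core of compound 1, fluoro in place of hydrogen on an aromatic carbon gives, in this assay, an at least 1.5-fold higher number from compound 1 to compound 4 (0.17 log units; that floor lies within the scatter), and with that floor inside the scatter, this does not firmly establish a real change. Compound 4 gives > 50000 nM, which is a limit of the assay and not a number. Whether the change has the same size on both cores cannot be said, because neither step has a readable size and the step on the other core cannot be read at all: the limit of > 50000 nM in this assay, at which 3 of the 4 values shown sit.

Still open, going by these compounds, is whether an amine or a carboxylic acid on the same aromatic carbon would shift the read-out on the shared core. On these data alone, the true values of compound 2, compound 3 and compound 4 also remain unknown.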